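Swapping Bromo for Methyl: An Expectation for Compound 4

A few compounds are considered here, and "the series" means these few. Any claim that something is new, unique, unknown or untested is made for them only; others in the source may bear on it.

Compound 1 `O=C1CCCCC/C1=C\c1cccc(Br)c1` and compound 2 `O=C1CCCCC/C1=C\c1ccc(Br)cc1` contain the same atoms joined differently; the difference between the two cores is not broken down here. In a functional assay on CCRF-CEM cells (Homo sapiens) for inhibition (on this read-out lower numbers stand for stronger inhibition and higher numbers for weaker inhibition), compound 1 gives 137000 nM, while compound 2 gives 42800 nM, the lowest of the three measured numbers. Compound 3 `Cc1cccc(/C=C2\CCCCCC2=O)c1` arises from compound 1 by one change, (methyl in place of bromo on an aromatic carbon), and in this assay compound 3 gives 170000 nM, a step of a 1.2-fold higher number from compound 1 to compound 3 (0.09 log units; within the scatter). Compound 4 `Cc1ccc(/C=C2\CCCCCC2=O)cc1` arises from compound 2 by the same kind of change, (methyl in place of bromo on an aromatic carbon); here the methyl stands para to a group of 9 heavy atoms, whereas in compound 3 it stands meta to a group of 9 heavy atoms. For compound 4 in this assay a similarly small step is expected, a 1.2-fold higher number from compound 2 to compound 4 (0.08 log units; within the scatter), because the measured step of a 1.2-fold higher number from compound 1 to compound 3 (0.09 log units; within the scatter) stayed within the scatter. Compound 4 is estimated at 52000 nM, between 25000 nM and 120000 nM.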

Compound 4, half-maximal inhibitory concentration: > 500000 nM
Compound 4 gave a limit, no number (the forecaster's own chance of this, stated with the estimate: 5%); at least 9.6-fold (0.98 log units) between middle value and limit.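

In this assay, compound 4 gave only a limit of the assay, > 500000 nM, and not a number. Even so, methyl in place of bromo gives an at least 11-fold higher number from compound 2 to compound 4 (1.06 log units; beyond the scatter), so the small step seen on one core did not carry over to the other: the same change on two cores in this assay, a 1.2-fold higher number (0.09 log units; within the scatter) from compound 1 to compound 3 and an at least 11-fold higher number (1.06 log units; beyond the scatter) from compound 2 to compound 4, at least 9.4-fold (0.97 log units) apart, beyond the scatter of two such steps This shows that the effect of this change depends on the core it is made on, but it does not show why, and the true size of the step remains unknown.

The compounds shown leave open how other groups on the same aromatic carbon, such as an amine or a carboxylic acid, would behave. They also leave open whether an ethyl group would track bromo or methyl on either core.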